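Methyl for methoxy on a second core, a step awaited

The source may report more compounds than this note shows. Statements on the series, on what has been measured and on what is new or still open speak of the compounds shown alone.

Of the compounds shown here, three have been measured in an assay on HeLa cells for displacement of a labelled ligand from 5-hydroxytryptamine receptor 6 (Homo sapiens); on this read-out higher numbers stand for weaker inhibition and lower numbers for stronger inhibition. Compound 1 `Cc1ccc(S(=O)(=O)c2n[nH]c3ccc(N4CCN(C)CC4)cc23)cc1` gives 4.9 nM, compound 3 `COc1ccc(S(=O)(=O)c2n[nH]c3ccc(N4CCN(C)CC4)cc23)cc1` gives 12 nM, and compound 2 `COc1ccc(S(=O)(=O)c2n[nH]c3cc(N4CCNCC4)ccc23)cc1` gives 124 nM, the highest of the three. Compound 1 differs from compound 3 by methyl in place of methoxy on an aromatic carbon, and this change made a 2.4-fold lower number from compound 3 to compound 1 (0.39 log units; beyond the scatter). Compound 2 differs from compound 3 in its core, and the difference between the two cores is not broken down here. Compound 4 `Cc1ccc(S(=O)(=O)c2n[nH]c3cc(N4CCNCC4)ccc23)cc1` repeats the same change on the core of compound 2: methyl in place of methoxy on an aromatic carbon. Because the step of a 2.4-fold lower number from compound 3 to compound 1 (0.39 log units; beyond the scatter) was modest, a step of similar size is expected from compound 2 to compound 4, namely a 2.5-fold lower number from compound 2 to compound 4 (0.39 log units; beyond the scatter). In this assay compound 4 is therefore estimated at 50 nM, with a likely range from 20 nM to 150 nM.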

Compound 4, inhibition constant: 27 nM
Compound 4: the middle estimate sits 1.9-fold (0.27 log units) above what was measured; the measured number falls inside the stated range.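

The change from 4-methoxyphenyl to 4-methylphenyl made a 4.6-fold lower number from compound 2 to compound 4 (0.66 log units; beyond the scatter) in this assay, so the methyl compound again gives the lower number on this second core. The two steps agree in direction and do not differ in size beyond what repeated measurement would allow: the same change on two cores in this assay, a 2.4-fold lower number (0.39 log units; beyond the scatter) from compound 3 to compound 1 and a 4.6-fold lower number (0.66 log units; beyond the scatter) from compound 2 to compound 4, 1.9-fold (0.27 log units) apart, within the scatter of two such steps

For the compounds shown here, this shows that the change carried across these two cores in this assay, but with only two pairs it does not show that it would carry to any other core, nor does it explain the lower numbers. The compounds shown leave open what a chlorine atom, an ethyl group or a trifluoromethyl group on the same aromatic carbon would give on either core. They also leave open whether any such group would follow the same course on both cores.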